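From Methoxy to Hydroxy: Estimating Compound 4

A few compounds are considered here, and "the series" means these few. Any claim that something is new, unique, unknown or untested is made for them only; others in the source may bear on it.

Compound 1, `COc1ccc(NC(=O)c2nc(-c3cc(OC)c(OC)c(OC)c3)n(-c3ccc(OC)cc3)n2)cc1`: 51%
Compound 2, `COc1ccc(-n2nc(C(=O)Nc3ccc(C)cc3)nc2-c2cc(OC)c(OC)c(OC)c2)cc1`: 42%
Compound 3, `COc1ccc(-n2nc(C(=O)Nc3ccc(C(=O)O)cc3)nc2-c2cc(OC)c(OC)c(OC)c2)cc1`: 60%

These three share one core and were all measured in a functional assay on the whole organism for inhibition, with Rattus norvegicus as the target, read by paw edema, with stated times of 30 min and 5 h, at a dose of 0.28 mmol/kg by the oral route; a higher number here means more inhibition at the dose given (going by the name of the read-out), a lower number less inhibition. Compound 1 stands second highest of the three numbers, yet its gaps to compound 2 and to compound 3 both lie within the usual scatter, so no order among the three can be claimed from compound 1 alone.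

Compound 4, `COc1ccc(-n2nc(C(=O)Nc3ccc(O)cc3)nc2-c2cc(OC)c(OC)c(OC)c2)cc1`, differs from compound 1 by hydrogen in place of methyl on an oxygen on an aromatic ring. For the measured compounds named here, no measured step swaps methoxy for hydroxy, so the closest guides are a number 9 percentage points lower from compound 1 to compound 2 (within the scatter) and a number 9 percentage points higher from compound 1 to compound 3 (within the scatter), both within the scatter, while a number 18 percentage points higher from compound 2 to compound 3 (beyond the scatter). Changes at this position have so far moved the number little, so a step of a number 3 percentage points higher from compound 1 to compound 4 (within the scatter) is expected, not beyond the scatter. Compound 4 is therefore estimated at 54%, with a range from 40% to 68%.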

Compound 4, a percentage reported as inhibition, in the whole organism at one dose (the size of the read-out at that dose, not a potency): 27%
Beside the measured number, compound 4's estimate is 27 percentage points above it; measured number below the stated range.
By their numbers in this assay, from the lowest: compound 4; then compounds 2, 1 and 3 (each within the scatter of the next, the first and the last beyond it).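

Hydrogen in place of methyl on this oxygen gives a number 24 percentage points lower from compound 1 to compound 4 (beyond the scatter) in this assay, whereas neither earlier step away from compound 1 went beyond the scatter. For the compounds shown here, the other two comparisons agree, with a number 15 percentage points lower from compound 2 to compound 4 (beyond the scatter) and a number 33 percentage points lower from compound 3 to compound 4 (beyond the scatter), so this position is more sensitive than the earlier compounds suggested, and hydroxy stands apart from methoxy, methyl and carboxy here. Nothing available explains this difference. On these data alone, whether it is specific to hydroxy stays open. An amine at the same place, or a longer chain such as ethoxy, would help to show this.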